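This account rests on a few compounds, and the source may have more. Where it says the series, first, only, none or still open, it means among the compounds named here.

Compound 1, `CCOc1nc(N)nc2c1ncn2/C=C1/CC1(CO)CO`: in an ADME assay on MOLT-3 cells (Homo sapiens) for cytotoxicity, with a stated time of 7 days (a higher number here means that more compound is tolerated, a lower number that less compound is tolerated), compound 1 gives only a limit of the assay, > 20000 nM.
Compound 2, `Nc1nc2c(ncn2/C=C2/CC2(CO)CO)c(=O)[nH]1`: in this assay compound 2 likewise gives only a limit, > 20000 nM.
Compound 3, `Nc1nc(N2CCCC2)c2ncn(/C=C3/CC3(CO)CO)c2n1`: in this assay compound 3 has "not determined" (no result reported).

Among the compounds with values here, no step between measured compounds can be drawn here. Compound 3 stands without a number of its own; the two values that are known both sit at the limit of > 20000 nM in this assay, at which 2 of the 3 values shown sit. Compound 4, `CCCCNc1nc(N)nc2c1ncn2/C=C1/CC1(CO)CO`, differs from compound 3 by butylamino in place of pyrrolidin-1-yl on an aromatic carbon. Within the data shown here, with no measured step to lean on, the expectation is that compound 4 also stays at the limit rather than moving beyond the scatter in either direction. Compound 4 is therefore expected near 20000 nM, within 10000 nM to 40000 nM.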

Compound 4, half-maximal cytotoxic concentration: > 20000 nM
Compound 4: a limit, no number; the forecaster's own chance of this, stated with the estimate: 80%; the middle value sits exactly at the limit.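

In this assay, within the data shown here, no step from compound 1 to compound 4 can be read, since both give only a limit: the limit of > 20000 nM in this assay, at which 3 of the 4 values shown sit. The compounds shown leave open which change on this aromatic carbon, if any, would bring a measurable half-maximal cytotoxic concentration.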